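Series notes: amide-type chain in place of butoxy at compound 2

The source may hold more compounds than are shown below. What is called first, only, known or untested is meant among the compounds shown, and "the series" means these compounds.

Two compounds of this series have a number in a functional assay (trachea) for antagonist activity, with Cavia porcellus as the target; a higher number here means a more potent compound, by a factor of ten per unit of this negative logarithm, a lower number a less potent compound. Compound 1 `COc1cc(-c2nn[nH]n2)ccc1Cn1ncc2ccc(NC(=O)OC3CCCC3)cc21` gives 7.7. Going by the values given here, compound 2 `CCCCOC(=O)Nc1ccc2cnn(Cc3ccc(-c4nn[nH]n4)cc3OC)c2c1` gives 7.1, the lower of the two numbers; the only measured step is a number 0.60 log units lower from compound 1 to compound 2 (beyond the scatter), a modest drop beyond the scatter. Compound 3 `CCCCC(CC)C(=O)Nc1ccc2cnn(Cc3ccc(-c4nn[nH]n4)cc3OC)c2c1` carries 1-ethylpentyl in place of butoxy on a carbonyl carbon, so the butoxy is gone and the 1-ethylpentyl chain sits directly on the carbonyl carbon. Among the compounds with values here, no measured step covers a change of this kind; the step of a number 0.60 log units lower from compound 1 to compound 2 (beyond the scatter) alters only the alkyl on the oxygen and shows merely that this end of the molecule can move this assay by a modest amount. That single step has uncertain bearing here. Compound 3 is therefore expected to show a step of a number 0.10 log units lower from compound 2 to compound 3 (within the scatter), not clearly beyond the scatter in either direction. The estimate for compound 3 is 7, in a range from 6.3 to 7.7.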

Compound 3, negative logarithm of the antagonist equilibrium constant: 7.1
Beside the measured number, compound 3's estimate is 0.10 log units below it; low and high end bracket the measured number.
By their numbers in this assay, from the lowest: compounds 2 and 3 (each within the scatter of the next); then compound 1.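

In this assay, 1-ethylpentyl in place of butoxy on the carbonyl carbon gives no change at the digits printed from compound 2 to compound 3 (within the scatter), so within this pair, an amide-type chain without the butoxy oxygen holds the level of compound 2. The cyclopentyloxy group of compound 1 remains ahead of this new chain, with a number 0.60 log units lower from compound 1 to compound 3 (beyond the scatter), and thus neither open-chain compound reaches compound 1 at this position. No supporting measurement is available to explain either step.

The exchange removes the oxygen and changes the chain at once, so the compounds shown do not separate the contribution of each, and the two contributions may offset one another. A cyclopentyl or butyl group directly on the carbonyl carbon would address this, while a chain bearing an amine or a carboxylic acid would test how far this position tolerates other groups.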